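Hydrogen in place of hydroxy on an aromatic nitrogen

This account rests on a few compounds, and the source may have more. Where it says the series, first, only, none or still open, it means among the compounds named here.

In an ADME assay on cells (Hepatocyte, Homo sapiens) for metabolic stability, with a stated time of 30 min (a lower number here means that less of the compound is left, a higher number that more of the compound is left), compound 1 `O=c1cc(N2CCN(CC3CCCCC3)CC2)sc2c(NO)cc(C(F)(F)F)cc12` gives 19.1%, the highest of the three numbers and beyond the scatter from the other two. Compound 2 `O=C(OC1CCC(CN2CCN(c3cc(=O)c4cc(C(F)(F)F)cc([N+](=O)[O-])c4s3)CC2)CC1)c1ccncc1` gives 1%, and compound 3 `CC(=O)OC1CCC(CN2CCN(c3cc(=O)c4cc(C(F)(F)F)cc([N+](=O)[O-])c4s3)CC2)CC1` gives 0%. Compound 4 `Nc1cc(C(F)(F)F)cc2c(=O)cc(N3CCN(CC4CCCCC4)CC3)sc12` differs from compound 1 by hydrogen in place of hydroxy on a nitrogen on an aromatic ring, with hydrogen in place of hydroxy on a nitrogen on an aromatic ring. For the measured compounds named here, the only measured step, a number 1 percentage points lower from compound 2 to compound 3 (within the scatter), concerns a different place in the structure, so it offers no direct guide to this change. With no measured evidence for a shift in this assay, the expected step is a number 0.9 percentage points higher from compound 1 to compound 4 (within the scatter), which is none beyond the scatter. For compound 4 the estimated value is 20%, with an expected range from 6% to 40%.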

Compound 4, percent of the compound remaining: 0.9%
Estimate against measurement, compound 4: 19.1 percentage points above; the whole stated range lies above it.
By their numbers in this assay, from the lowest: compounds 3, 4 and 2 (each within the scatter of the next); then compound 1.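

In this assay, for the compounds shown here, hydrogen in place of hydroxy on a nitrogen on an aromatic ring gives a number 18.2 percentage points lower from compound 1 to compound 4 (beyond the scatter) and shows that this position, which did not vary among the earlier compounds, matters for the read-out. Of this pair, the hydroxyamino compound keeps more of the parent compound than the amino compound does. Nothing shown gives a reason for this step.

What the compounds leave open is how methylamino or acetylamino at this place would compare. Going by these compounds, it also remains open whether hydroxyamino gives the same step on a different side chain.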